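This account rests on a few compounds, and the source may have more. Where it says the series, first, only, none or still open, it means among the compounds named here.

Measured in a functional assay on A549 cells (Homo sapiens) for inhibition, read by CCK-8 assay, with a stated time of 72 h, tested at 1 uM; on this read-out higher numbers stand for a stronger effect at the one concentration tested and lower numbers for a weaker effect:

Compound 1, `CN(C)C(=O)c1cc2cnc(Nc3ccc(S(=O)(=O)NCCCCN=C=S)cc3)nc2n1C1CCCC1`: 39.4%
Compound 2, `CN(C)C(=O)c1cc2cnc(Nc3ccc(C(=O)NCCCCCN=C=S)cc3)nc2n1C1CCCC1`: 29.3%

Among the two measured compounds, compound 2 stands lowest in this assay, with compound 1 as its only neighbour; the step between them is a number 10.1 percentage points lower from compound 1 to compound 2 (beyond the scatter), which lies beyond the scatter. That step exchanges the whole linker between the aromatic carbon and the isothiocyanate, so it says little about a change that keeps the amide linker and alters only the length of the saturated chain.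

Compound 3, `CN(C)C(=O)c1cc2cnc(Nc3ccc(C(=O)NCCCCCCCN=C=S)cc3)nc2n1C1CCCC1`, differs from compound 2 by a group of 5 heavy atoms (3 carbon, 1 nitrogen, 1 sulfur; no ring) in place of a group of 3 heavy atoms (1 carbon, 1 nitrogen, 1 sulfur; no ring), on a saturated chain carbon, five bonds along the chain from an amide-type nitrogen. Among the compounds with values here, no measured step in this assay follows a change of this kind, and the one step that is known concerns a different part of the molecule. The account therefore carries no measured ground for a shift in either direction, and compound 3 is expected to lie close to compound 2, with a step of a number 0.3 percentage points lower from compound 2 to compound 3 (within the scatter) that is not expected to exceed the scatter. The estimate for compound 3 in this assay is 29%, with a range from 12% to 46%.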

Compound 3, a percentage reported as inhibition, at one concentration (the size of the read-out at that concentration, not a potency): 73.7%
Estimate against measurement, compound 3: 44.7 percentage points below, outside the stated range (above it).
By their numbers in this assay, from the lowest: compound 2; then compound 1; then compound 3.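

In this assay, the change that keeps the amide linker and the terminal isothiocyanate and alters only the saturated chain gives a number 44.4 percentage points higher from compound 2 to compound 3 (beyond the scatter), so this position, five bonds along the chain from an amide-type nitrogen, responds strongly to a group of 5 heavy atoms in place of a group of 3 heavy atoms. The earlier step, a number 10.1 percentage points lower from compound 1 to compound 2 (beyond the scatter), exchanged the whole linker and could not separate chain length from the other differences, whereas here the chain is the only thing that differs, and the step is clearly the larger of the two. No measurement at hand says what lies behind this rise in the reading at the one concentration tested.

The compounds shown leave open whether a longer chain would raise the reading further or lose the gain, and whether a chain of intermediate length would already give part of it. They also leave open whether the gain depends on the isothiocyanate, which an amine at the chain end would test, and whether the same lengthening would act on the sulfonamide linker of compound 1.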